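The source may hold more compounds than are shown below. What is called first, only, known or untested is meant among the compounds shown, and "the series" means these compounds.

Values in a functional assay on SW480 cells (Homo sapiens) for antiproliferative activity, read by MTT assay, with a stated time of 48 h (a higher number here means a weaker inhibitor, a lower number a stronger inhibitor), so far:

Compound 1 `CCCC(CCO)n1cnc2c(Cl)ncnc21` gives > 50000 nM (a limit of the assay)
Compound 2 `CCCCC(CCO)n1cnc2c(Cl)ncnc21` gives > 50000 nM (a limit of the assay)
Compound 3 `CCCCCCCCCCC(CCO)n1cnc2c(Cl)ncnc21` gives 3160 nM (a measured number)

For the measured compounds named here, only compound 3 has a readable number in this assay so far. The remaining evidence is the limit of > 50000 nM in this assay, at which 2 of the 3 values shown sit, and no more.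

Compound 4 `CCCCCCCCCCCC(CCO)n1cnc2c(Cl)ncnc21` arises from compound 3 by a single change: methyl in place of hydrogen on a saturated chain carbon, ten or more bonds along the chain from an aromatic nitrogen that is, methyl in place of hydrogen on a saturated chain carbon, ten or more bonds along the chain from an aromatic nitrogen.

Going by the values given here, two measured steps bear on this change: an at least 15-fold lower number from compound 1 to compound 3 (1.19 log units; beyond the scatter) and an at least 15-fold lower number from compound 2 to compound 3 (1.19 log units; beyond the scatter) in both of which far more chain enters than a single methyl, as heptyl and as hexyl. The methyl step closest in kind, a step that the two limits leave unreadable from compound 1 to compound 2 gives no size to work from. Among these three compounds, the longer chain of compound 3 goes with the lower number, and no compound goes against that, though three compounds make a thin basis.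

One more methyl on a chain already this long is therefore expected to shift the number only slightly, if at all, and towards lower values. The expected change is a 1.3-fold lower number from compound 3 to compound 4 (0.10 log units; within the scatter) and it is expected to stay within the scatter. For compound 4 the estimated value is 2500 nM with an expected range from 1000 nM to 6500 nM in this assay once measured.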

Compound 4, half-maximal inhibitory concentration: 5290 nM
For compound 4 the middle estimate is 2.1-fold (0.33 log units) below the measured one, within the range that was stated.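

In this assay, the first step readable at this far position on the chain is a 1.7-fold higher number from compound 3 to compound 4 (0.22 log units; within the scatter); it lies within the scatter, so methyl in place of hydrogen here leaves compound 3 and compound 4 indistinguishable. The long-chain compounds still stand apart from the short-chain ones, with an at least 9.4-fold lower number from compound 2 to compound 4 (0.97 log units; beyond the scatter) and an at least 9.4-fold lower number from compound 1 to compound 4 (0.97 log units; beyond the scatter), so the separation seen with compound 3 also holds for compound 4, while the added methyl brings no further readable drop in the number. Heptyl in place of hydrogen can now be read in two settings: the same change on two cores in this assay, an at least 15-fold lower number (1.19 log units; beyond the scatter) from compound 1 to compound 3 and an at least 9.4-fold lower number (0.97 log units; beyond the scatter) from compound 2 to compound 4; the limit leaves it open whether they differ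

Still open, on these data alone, is where, between the chain of compound 2 and that of compound 3, the number first becomes readable, since the short-chain end of the series gives no numbers: the limit of > 50000 nM in this assay, at which 2 of the 4 values shown sit. Also open is whether a longer chain than that of compound 4 keeps the number level or moves it, and whether an amine in place of the hydroxyl group would change the picture on the long chain.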